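Removing a Methyl from the Fused Core of Compound 3

The source may hold more compounds than are shown below. What is called first, only, known or untested is meant among the compounds shown, and "the series" means these compounds.

Compound 1 `COc1ccccc1-c1cc(O)c2cc(C)cnc2n1`: 26900 nM
Compound 2 `Cc1cc(C)c2c(O)cc(-c3ccc(Cl)cc3)nc2n1`: 6310 nM
Compound 3 `COc1ccc(-c2cc(O)c3c(C)cc(C)nc3n2)cc1`: 24000 nM

In a functional assay on PC-3 cells (Homo sapiens) (a higher number here means a weaker inhibitor of growth, a lower number a stronger inhibitor of growth), compound 3 gives 24000 nM. Among the three numbers it is separated beyond the scatter only from compound 2, by a 3.8-fold higher number from compound 2 to compound 3 (0.58 log units; beyond the scatter); its gap to compound 1 lies within the scatter. Compound 4 `COc1ccc(-c2cc(O)c3ccc(C)nc3n2)cc1` differs from compound 3 by hydrogen in place of methyl on an aromatic carbon. Within the data shown here, the single measured step, the swap of methoxy for chloro between compound 2 and compound 3, concerns another part of the molecule and does not inform this change; no measured pair differs by a methyl alone. The account therefore expects no step beyond the scatter in this assay, so for compound 4 it estimates 26000 nM (range 9000 nM to 75000 nM), a step of a 1.1-fold higher number from compound 3 to compound 4 (0.03 log units; within the scatter).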

Compound 4, concentration for 50% growth inhibition: > 100000 nM
Compound 4: no number, only a limit; the forecaster's own chance of this, stated with the estimate: 10%; middle value at least 3.8-fold (0.58 log units) away from the limit.
By their numbers in this assay, from the lowest: compound 2; then compounds 3 and 1 (each within the scatter of the next). At a limit, above all of these: compound 4.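

In this assay, among these compounds, the methyl opposite the ring nitrogen proves to count: hydrogen in its place gives an at least 4.1-fold higher number from compound 3 to compound 4 (0.61 log units; beyond the scatter) and so a step beyond the scatter at a place on the fused core that no earlier pair had touched. The value of compound 4 is > 100000 nM and it is a limit of the assay, not a number: the limit of > 100000 nM in this assay, at which 1 of the 4 values shown sits.

The compounds shown leave open whether an ethyl, a trifluoromethyl or an amine at this place would keep the growth inhibition of compound 3. Also open, on these data alone, is whether the same step would appear with the chloro of compound 2.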